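The source may hold more compounds than are shown below. What is called first, only, known or untested is meant among the compounds shown, and "the series" means these compounds.

The measured compounds:

Compound 1, `CCNC(=O)c1noc(-c2cc(C(C)C)c(O)cc2O)c1-c1ccn(CC)n1`, in a functional assay on HCT-116 cells (Homo sapiens) for inhibition (a lower number here means a stronger inhibitor, a higher number a weaker inhibitor), gives 25 nM.
Compound 2, `CCCn1ccc(-c2c(C(=O)NCC)noc2-c2cc(C(C)C)c(O)cc2O)n1`, in this assay gives 49 nM.
Compound 3, `CCNC(=O)c1noc(-c2cc(C(C)C)c(O)cc2O)c1-c1cnn(CC)c1`, in this assay gives 26 nM.

The three share one core, with the difference between the core of compound 1 and that of compound 3 being (1-ethyl-1H-pyrazol-4-yl in place of 1-ethyl-1H-pyrazol-3-yl on an aromatic carbon). That change made a step of a 1.0-fold higher number from compound 1 to compound 3 (0.02 log units; within the scatter), so compound 1 and compound 3 cannot be told apart in this assay. Compound 2 differs from compound 1 by methyl in place of hydrogen on a saturated chain carbon, two bonds along the chain from an aromatic nitrogen, and the step was a 2.0-fold higher number from compound 1 to compound 2 (0.29 log units; within the scatter). Between compound 2 and compound 3 the step was a 1.9-fold lower number from compound 2 to compound 3 (0.28 log units; within the scatter).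

Compound 4, `CCNC(=O)c1noc(-c2cc(C(C)C)c(O)cc2O)c1-c1cnn(C(C)C)c1`, has not been measured in this assay. It differs from compound 3 by methyl in place of hydrogen on a saturated chain carbon bound to an aromatic nitrogen and a saturated chain carbon. Among the measured compounds shown here, this is the same kind of change as the one from compound 1 to compound 2, not the same change: there the methyl entered on a saturated chain carbon, two bonds along the chain from an aromatic nitrogen, whereas here it enters on a saturated chain carbon bound to an aromatic nitrogen and a saturated chain carbon. Resting on the step of a 2.0-fold higher number from compound 1 to compound 2 (0.29 log units; within the scatter), the expected step from compound 3 to compound 4 is a 1.5-fold higher number from compound 3 to compound 4 (0.19 log units; within the scatter), with added width. For the measured compounds named here, the place of the methyl differs from that in the measured pair, and no measured pair shows a change at this place. Compound 4 is therefore estimated at 40 nM in this assay, expected to fall between 15 nM and 110 nM.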

Compound 4, half-maximal inhibitory concentration: 21 nM
Compound 4: the middle estimate sits 1.9-fold (0.28 log units) above what was measured, and the stated range covers the measured number.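

In this assay, the methyl that turns ethyl into isopropyl gives a step of a 1.2-fold lower number from compound 3 to compound 4 (0.09 log units; within the scatter) and so has no effect that can be told from the scatter on this core, and the two steps for this kind of change do not differ measurably across the two cores: the same change on two cores in this assay, a 2.0-fold higher number (0.29 log units; within the scatter) from compound 1 to compound 2 and a 1.2-fold lower number (0.09 log units; within the scatter) from compound 3 to compound 4, 2.4-fold (0.39 log units) apart, within the scatter of two such steps. Compound 4 also cannot be told apart from compound 1, with a step of a 1.2-fold lower number from compound 1 to compound 4 (0.08 log units; within the scatter), whereas the step of a 2.3-fold lower number from compound 2 to compound 4 (0.37 log units; beyond the scatter) lies beyond the scatter but is modest, and it exchanges 1-propyl-1H-pyrazol-3-yl for 1-isopropyl-1H-pyrazol-4-yl as a whole. The agreement therefore shows only that a methyl added to the chain on the pyrazole nitrogen stayed a small step on both cores, not that the two steps share a size or a direction, and the methyl entered at a different place on the chain in each pair, so neither pair tests the other's change directly.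

The compounds shown leave open how 1-propyl-1H-pyrazol-4-yl and 1-isopropyl-1H-pyrazol-3-yl would compare, which would complete the set of chains on both pyrazole attachments. They also leave open whether a longer chain, or a chain ending in an amine or a carboxylic acid, would still give so small a step.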